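The source may report more compounds than this note shows. Statements on the series, on what has been measured and on what is new or still open speak of the compounds shown alone.

Measured so far:
Compound 1 `FC(F)(F)c1ccc(CSc2nc(Sc3ncccn3)cc(C(F)(F)F)n2)cc1`: > 50000 nM
Compound 2 `FC(F)(F)c1ccc(CSc2nc(Sc3ccccn3)cc(C(F)(F)F)n2)cc1`: 25200 nM

The series is read in a functional assay on PC-3 cells (Homo sapiens) for inhibition, read by MTT assay, with a stated time of 72 h; a lower number here means a stronger inhibitor, a higher number a weaker inhibitor. Compound 1 gives > 50000 nM, which is a limit of the assay and not a number. For the measured compounds named here, compound 2 gives 25200 nM, the only true number so far.

Compound 3 `FC(F)(F)c1ccc(CSc2nc(Sc3nnnn3-c3ccccc3)cc(C(F)(F)F)n2)cc1` changes the group on the same sulfur: 1-phenyl-1H-tetrazol-5-yl in place of pyridin-2-yl on a sulfur. In words, 1-phenyl-1H-tetrazol-5-yl stands in place of pyridin-2-yl, a larger group with more ring nitrogens.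

Going by the values given here, one measured step bears on this, the earlier exchange on that sulfur, an at least 1.9-fold lower number from compound 1 to compound 2 (0.29 log units; that floor lies within the scatter). That step is small, and it gives no direction for a group of a different kind. No step beyond the scatter is therefore expected, and compound 2 at 25200 nM remains the anchor. The expected step is a 1.0-fold lower number from compound 2 to compound 3 (0.00 log units; within the scatter). A result at the assay limit would also fit (the limit of > 50000 nM in this assay, at which 1 of the 2 values shown sits).

For compound 3 the estimate is 25000 nM, with an expected range of 8000 nM to 50000 nM.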

Compound 3, half-maximal inhibitory concentration: 45300 nM
Beside the measured number, compound 3's estimate is 1.8-fold (0.26 log units) below it; the range from low to high includes it.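

In this assay, replacing a single six-membered aromatic ring on this sulfur with 1-phenyl-1H-tetrazol-5-yl, which brings a five-membered aromatic ring and a second, carbon-only six-membered aromatic ring, gives a 1.8-fold higher number from compound 2 to compound 3 (0.25 log units; within the scatter). So far, then, a very different group on this sulfur cannot be told apart from pyridin-2-yl, and compound 2 and compound 3 are the only two true numbers available for comparison. The exchange for pyrimidin-2-yl reads an at least 1.1-fold lower number from compound 1 to compound 3 (0.04 log units; that floor lies within the scatter), a floor that sets no order, and compound 1 remains a limit of the assay and not a number: the limit of > 50000 nM in this assay, at which 1 of the 3 values shown sits.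

The compounds shown carry only aromatic rings on this sulfur, so it remains open whether a non-aromatic group there, such as a primary amine, a carboxylic acid or a longer alkyl chain, would give a step beyond the scatter. Also open, as far as these compounds go, is whether changes elsewhere, for example at the trifluoromethyl group on the shared core or at the benzyl group on the other sulfur, would move the number more than this exchange does.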